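Swapping the five-membered ring on the carbonyl

A few compounds are considered here, and "the series" means these few. Any claim that something is new, unique, unknown or untested is made for them only; others in the source may bear on it.

Of the compounds shown here, three have been measured in an assay on RBL-1 cells for inhibition of Polyunsaturated fatty acid 5-lipoxygenase (Rattus norvegicus); a higher number here means a weaker inhibitor, a lower number a stronger inhibitor: compound 1, `O=C(/C=C\N(O)Cc1ccc(-c2ccccc2)cc1)c1ccc(F)cc1`, gives 3000 nM; compound 2, `O=C(/C=C\N(O)Cc1ccc(-c2ccccc2)cc1)c1ccsc1`, gives 3000 nM; compound 3, `O=C(/C=C\N(O)Cc1ccc(-c2ccccc2)cc1)c1ccco1`, gives 3100 nM.

Compound 3 cannot be told apart from its two neighbours on these numbers: the steps of a 1.0-fold higher number from compound 1 to compound 3 (0.01 log units; within the scatter) and a 1.0-fold higher number from compound 2 to compound 3 (0.01 log units; within the scatter) both sit within the scatter, as does no change at the digits printed from compound 1 to compound 2 (within the scatter). Three different groups on the carbonyl carbon have thus given the same reading.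

Compound 4, `O=C(/C=C\N(O)Cc1ccc(-c2ccccc2)cc1)c1cccs1`, differs from compound 3 in one place: thiophen-2-yl in place of furan-2-yl on a carbonyl carbon. All three measured steps bear on this change, since each of them also exchanges the group on the carbonyl carbon, and each of them is within the scatter. The exchange of a furan for a thiophene has already been seen once, in a 1.0-fold higher number from compound 2 to compound 3 (0.01 log units; within the scatter), without effect beyond the scatter. The step of a 1.0-fold lower number from compound 3 to compound 4 (0.01 log units; within the scatter) is therefore expected to be no larger than the scatter, in no particular direction.

Compound 4 is estimated at 3000 nM in this assay, with a range from 1500 nM to 6000 nM.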

Compound 4, half-maximal inhibitory concentration: > 25000 nM
Compound 4 ended at the assay's limit; the forecaster's own chance of this, stated with the estimate: 5%; middle value at least 8.3-fold (0.92 log units) from the limit.
By their numbers in this assay, from the lowest: compounds 1, 2 and 3 (each within the scatter of the next). At a limit, above all of these: compound 4.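

The reading of compound 4 in this assay is a limit of the assay and not a number: the limit of > 25000 nM in this assay, at which 1 of the 4 values shown sits.

The group on the carbonyl carbon, which had made no difference beyond the scatter across compound 1, compound 2 and compound 3, does matter after all: thiophen-2-yl in place of furan-2-yl gives an at least 8.0-fold higher number from compound 3 to compound 4 (0.90 log units; beyond the scatter), and thiophen-2-yl in place of 4-fluorophenyl gives an at least 8.3-fold higher number from compound 1 to compound 4 (0.92 log units; beyond the scatter). The sharpest contrast is within the thiophenes, where thiophen-2-yl in place of thiophen-3-yl gives an at least 8.3-fold higher number from compound 2 to compound 4 (0.92 log units; beyond the scatter), so the reading at this position depends on how the thiophene is attached to the carbonyl carbon and not merely on a thiophene being present; furan-2-yl and thiophen-2-yl also match in their counts of heavy atoms, donors and acceptors, so those counts do not separate compound 3 from compound 4.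

The reading of compound 4 gives only a limit. Going by these compounds, the true size of these steps stays open. Also open, on these data alone, is whether a 5-methylthiophen-2-yl or a pyridin-2-yl on the carbonyl carbon would read like compound 3 or like compound 4.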